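Notes on a third compound in the series

The compounds below may be only part of what the source reports. "The series", "measured", "known", "first", "only" and "open" are said of these compounds alone.

Measured in a functional assay on SK-OV-3 cells (Homo sapiens) for inhibition (a lower number here means a stronger inhibitor of growth, a higher number a weaker inhibitor of growth), so far:
compound 1 `COc1cc(/C=C/C(=O)c2cccc(-n3cc(-c4ccccc4)[nH]c3=O)c2)cc(OC)c1OC`: 3270 nM
compound 2 `COc1ccc(-c2cn(-c3cccc(C(=O)/C=C/c4cc(OC)c(OC)c(OC)c4)c3)c(=O)[nH]2)cc1`: 4600 nM

Compound 2 carries the larger of the two figures, but a 1.4-fold higher number from compound 1 to compound 2 (0.15 log units; within the scatter) lies within the scatter, so the two compounds cannot be told apart on this assay. Going by the values given here, the only structural change seen so far is that single methoxy added to the pendant aryl ring.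

Compound 3 `COc1cc(/C=C/C(=O)c2cccc(-n3cc(-c4cc(OC)c(OC)c(OC)c4)[nH]c3=O)c2)cc(OC)c1OC` is not yet measured. It differs from compound 2 by 3,4,5-trimethoxyphenyl in place of 4-methoxyphenyl on an aromatic carbon, that is, two further methoxy groups on the same ring that already took one methoxy going from compound 1 to compound 2. Among the compounds with values here, the only step that bears on it is that one, and it stayed within the scatter. Extending the same ring in the same way gives no ground to expect a step beyond the scatter, in either direction. For compound 3 the expected outcome in this assay is 5500 nM, with the range 2200 nM to 14000 nM. This estimate means a step of a 1.2-fold higher number from compound 2 to compound 3 (0.08 log units; within the scatter), a change not expected to exceed the scatter.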

Compound 3, concentration for 50% growth inhibition: 5120 nM
Compound 3: the middle estimate sits 1.1-fold (0.03 log units) above what was measured; low and high end bracket the measured number.
By their numbers in this assay, from the lowest: compounds 1, 2 and 3 (each within the scatter of the next).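

Going by these compounds alone, at the position on an aromatic carbon of a five-membered aromatic ring with 2 nitrogen, the earlier compounds showed only what a single methoxy does; in this assay, the further exchange of 4-methoxyphenyl for 3,4,5-trimethoxyphenyl now gives a 1.1-fold higher number from compound 2 to compound 3 (0.05 log units; within the scatter). The whole change from phenyl to 3,4,5-trimethoxyphenyl, the largest one available at this position in the series, gives a 1.6-fold higher number from compound 1 to compound 3 (0.19 log units; within the scatter), so even three methoxy groups on this ring leave this assay unable to separate the compounds, and phenyl, 4-methoxyphenyl and 3,4,5-trimethoxyphenyl read alike here. No supporting data accompany these numbers to account for this lack of separation.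

From the compounds shown here alone, all the groups compared at this position are phenyl rings carrying hydrogen or methoxy, so it remains open whether an amine, a carboxylic acid or a fluorine on that ring, or a longer alkyl chain in place of the ring, would give a step beyond the scatter. Going by these compounds, the rest of the molecule is the same in all three compounds, so whether this position stays as insensitive on a different core is also open.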